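From a Methylphenyl Ether to a Dichlorophenyl Ether

The source may hold more compounds than are shown below. What is called first, only, known or untested is meant among the compounds shown, and "the series" means these compounds.

Compound 3 `Cc1ccccc1Oc1ccc(N2CCC[C@H]2CC(=O)O)cc1` gives 5600 nM in a functional assay on cells for agonist activity at Free fatty acid receptor 1 (Mus musculus), read by FLIPR and calcium flux, with a stated time of 100 s (a higher number here means that more compound is needed for the effect, a lower number that less compound is needed), the highest of the two numbers reported. Its nearest neighbour is compound 1 `Cc1ccccc1Oc1ccc(N2C[C@@H](C(F)(F)F)C[C@H]2CC(=O)O)cc1`, which gives 330 nM; the measured step of a 17-fold higher number from compound 1 to compound 3 (1.23 log units; beyond the scatter) is large. For compound 2 `Cc1ccccc1COc1ccc(N2CCC[C@H]2CC(=O)O)cn1` the result in this assay is only a limit, > 33000 nM (the limit of > 33000 nM in this assay, at which 1 of the 3 values shown sits).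

Compound 4 `O=C(O)C[C@@H]1CCCN1c1ccc(Oc2ccc(Cl)cc2Cl)cc1` differs from compound 3 at the aryl ether: 2,4-dichlorophenyl in place of 2-methylphenyl on an oxygen on an aromatic ring. Going by the values given here, none of the measured steps touches this part of the molecule; the single step measured concerns a trifluoromethyl against hydrogen on the saturated ring and offers no guide to an exchange on the aryl ether. The expected change is therefore modest and its direction uncertain; the estimated step is a 1.4-fold lower number from compound 3 to compound 4 (0.15 log units; within the scatter), which would not lie clearly beyond the scatter. Compound 4 is expected to give about 4000 nM in this assay, with a range from 1000 nM to 20000 nM.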

Compound 4, half-maximal effective concentration: 3200 nM
Beside the measured number, compound 4's estimate is 1.3-fold (0.10 log units) above it; the measured number falls inside the stated range.
By their numbers in this assay, from the lowest: compound 1; then compounds 4 and 3 (each within the scatter of the next). At a limit, above all of these: compound 2.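

In this assay, going by these compounds alone, the first exchange at the aryl ether, 2,4-dichlorophenyl in place of 2-methylphenyl on an oxygen on an aromatic ring, gives a 1.8-fold lower number from compound 3 to compound 4 (0.24 log units; within the scatter), so the two compounds cannot be told apart. Within the data shown here, the aryl ether therefore accepts two chlorine atoms in place of one methyl group without a change that can be read, while the only step beyond the scatter remains the one on the saturated ring, a 17-fold higher number from compound 1 to compound 3 (1.23 log units; beyond the scatter). Nothing measured here accounts for this result.

Going by these compounds, it remains open whether trifluoromethyl on the saturated ring would give a similar step with 2,4-dichlorophenyl on the oxygen as it does with 2-methylphenyl. On these data alone, how a phenyl ring bearing a single chlorine, a methoxy group or a nitrile would fare on the same oxygen also stays open.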